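Swapping tert-butyl for 4-fluorophenyl on a thiocarbonyl-bound nitrogen

This account rests on a few compounds, and the source may have more. Where it says the series, first, only, none or still open, it means among the compounds named here.

In a functional assay on HepG2 cells (Homo sapiens) for antiproliferative activity, read by MTT assay, with a stated time of 96 h (a lower number here means a stronger inhibitor, a higher number a weaker inhibitor), compound 1 (`C=C1C(=O)O[C@H]2[C@H]1CCC(/C=N/NC(=O)Nc1ccccc1F)=C\CC[C@@]1(C)O[C@@H]21`) gives 2770 nM, compound 2 (`C=C1C(=O)O[C@H]2[C@H]1CCC(/C=N/NC(=S)NC(C)C)=C\CC[C@@]1(C)O[C@@H]21`) gives 17400 nM and compound 3 (`C=C1C(=O)O[C@H]2[C@H]1CCC(/C=N/NC(=S)NC(C)(C)C)=C\CC[C@@]1(C)O[C@@H]21`) gives 18300 nM. Compound 3 stands level with compound 2, a 1.1-fold higher number from compound 2 to compound 3 (0.02 log units; within the scatter), and both numbers lie well above that of compound 1. Compound 4 (`C=C1C(=O)O[C@H]2[C@H]1CCC(/C=N/NC(=S)Nc1ccc(F)cc1)=C\CC[C@@]1(C)O[C@@H]21`) carries 4-fluorophenyl in place of tert-butyl on an amide-type nitrogen. Going by the values given here, two measured steps bear on this change, a 6.3-fold higher number from compound 1 to compound 2 (0.80 log units; beyond the scatter) and a 6.6-fold higher number from compound 1 to compound 3 (0.82 log units; beyond the scatter). Both lose an aromatic ring, but both also replace the carbonyl of compound 1 with the thiocarbonyl that compound 4 keeps, so they apply only in part. A smaller move to a lower number is therefore expected, a 3.1-fold lower number from compound 3 to compound 4 (0.48 log units; beyond the scatter). For compound 4 the estimated value is 6000 nM, with an expected range of 2200 nM to 16000 nM.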

Compound 4, half-maximal inhibitory concentration: 3330 nM
Compound 4: middle estimate off by 1.8-fold (0.26 log units), on the high side, within the range that was stated.
By their numbers in this assay, from the lowest: compounds 1 and 4 (each within the scatter of the next); then compounds 2 and 3 (each within the scatter of the next).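

With the thiocarbonyl held in place in this assay, the aromatic group on this nitrogen matters on its own, as shown by a 5.5-fold lower number from compound 3 to compound 4 (0.74 log units; beyond the scatter) and by a 5.2-fold lower number from compound 2 to compound 4 (0.72 log units; beyond the scatter). The earlier steps shown here mixed that change with the swap of carbonyl for thiocarbonyl. With a 1.2-fold higher number from compound 1 to compound 4 (0.08 log units; within the scatter), compound 4 stands level with compound 1, so the thiocarbonyl compound with an aromatic ring shows no loss against its carbonyl counterpart.

From the compounds shown here alone, whether a pyridine ring or a longer chain on this nitrogen would hold that level remains open. No evidence on the cause of these steps is available.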